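Swapping Imidazole for Fluoropyridine in a Weak Series

A few compounds are considered here, and "the series" means these few. Any claim that something is new, unique, unknown or untested is made for them only; others in the source may bear on it.

Compound 1 `CCN(c1ccc(C#N)c(Cl)c1)c1cc(-c2cncnc2)ccc1C`: > 30000 nM in a functional assay on CWR22R cells (Homo sapiens) for antiproliferative activity, read by CCK-8 assay, with a stated time of 6 days (on this read-out higher numbers stand for weaker inhibition and lower numbers for stronger inhibition), a limit of the assay rather than a number.
Compound 2 `CCN(c1ccc(C#N)c(C(F)(F)F)c1)c1cc(-n2ccnc2)ccc1C`: 16300 nM.
Compound 3 `CCN(c1ccc(C#N)c(Cl)c1)c1cc(-n2ccnc2)ccc1C`: > 30000 nM, again a limit of the assay.

Compound 3 therefore stands at the weak end of what is shown, with no number of its own, as the limit of > 30000 nM in this assay, at which 2 of the 3 values shown sit, makes plain. The step that the two limits leave unreadable from compound 1 to compound 3 is one the two limits leave unreadable, so nothing can be said of its size. The step of an at least 1.8-fold higher number from compound 2 to compound 3 (0.26 log units; that floor lies within the scatter) gives only a floor, and that floor lies within the scatter.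

Compound 4 `CCN(c1ccc(C#N)c(Cl)c1)c1cc(-c2ccc(F)nc2)ccc1C` carries 6-fluoropyridin-3-yl in place of 1H-imidazol-1-yl on an aromatic carbon. Compound 1 already shows that a six-membered aromatic ring at this position, with the chloro group kept, reaches the limit. The expectation for compound 4 is thus that it will also sit at or near the limit, and the step of a number no higher from compound 3 to compound 4 (the limit leaves the size open) is expected to be none that can be read beyond the scatter. The estimate for compound 4 is 30000 nM, expected to fall between 10000 nM and 100000 nM.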

Compound 4, half-maximal inhibitory concentration: 16500 nM
For compound 4 the middle estimate is 1.8-fold (0.26 log units) above the measured one; the measured number falls inside the stated range.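

In this assay compound 4 gives 16500 nM, the only actual number among the compounds shown that keep the chloro group, so a ring at this position can give a value that is not a limit. Changing the ring gives an at least 1.8-fold lower number from compound 3 to compound 4 (0.25 log units; that floor lies within the scatter) and an at least 1.8-fold lower number from compound 1 to compound 4 (0.25 log units; that floor lies within the scatter), so neither step shows a gain beyond the scatter. Each step is only a floor, because compound 1 and compound 3 carry limits of the assay rather than numbers: the limit of > 30000 nM in this assay, at which 2 of the 4 values shown sit.

Going by these compounds, whether an amine, a carboxylic acid or a methoxy group in place of the fluorine on the pyridine ring would shift the value stays open. Also open, on these data alone, is how the 6-fluoropyridin-3-yl ring would behave with trifluoromethyl in place of chloro on the shared core.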